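The compounds below may be only part of what the source reports. "The series", "measured", "known", "first", "only" and "open" are said of these compounds alone.

Working notes on the series.

Among the measured compounds shown here, compound 2 `CCC(C)NC(=O)NCCCOc1cccc(CN2CCCCC2)c1` gives 95.5 nM in an assay on isolated protein for inhibition of histamine H2 receptor (Cavia porcellus) (on this read-out higher numbers stand for weaker binding and lower numbers for tighter binding), the lower of the two numbers measured so far. For the measured compounds named here, its only neighbour in the data is compound 1 `O=C(NCCCOc1cccc(CN2CCCCC2)c1)NCc1ccccc1`, which in this assay gives 347 nM; the step of a 3.6-fold lower number from compound 1 to compound 2 (0.56 log units; beyond the scatter) separates them, and it is the only measured step in this set.

Compound 3 `COc1ccc(OC)c(NC(=O)NCCCOc2cccc(CN3CCCCC3)c2)c1` is the next member and has not yet been measured in this assay. It differs from compound 2 by 2,5-dimethoxyphenyl in place of sec-butyl on an amide-type nitrogen. Going by the values given here, the one measured step that bears on this position is the exchange of benzyl for sec-butyl from compound 1 to compound 2, which lowered the number by a modest but clear amount. Compound 3 replaces the sec-butyl with an aromatic ring carried directly on the same nitrogen, so the change goes in the opposite sense to that step, though the ring is not the one that was removed. The expectation is therefore a modest rise in the number rather than a further fall, with a broad range because the group is new to the series. For compound 3 the estimated result in this assay is 250 nM (range 60 nM to 1000 nM), which would mean an expected step of a 2.6-fold higher number from compound 2 to compound 3 (0.42 log units; beyond the scatter).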

Compound 3, dissociation constant: 158 nM
Compound 3: the middle estimate sits 1.6-fold (0.20 log units) above what was measured, within the range that was stated.
By their numbers in this assay, from the lowest: compounds 2 and 3 (each within the scatter of the next); then compound 1.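

Working from the new result: in this assay, 2,5-dimethoxyphenyl in place of sec-butyl on the amide-type nitrogen gives a 1.7-fold higher number from compound 2 to compound 3 (0.22 log units; within the scatter) and so leaves compound 2 and compound 3 indistinguishable, even though the entering group has 10 heavy atoms against 4 and brings an aromatic ring and 2 hydrogen-bond acceptors. The same group in place of benzyl gives a 2.2-fold lower number from compound 1 to compound 3 (0.34 log units; beyond the scatter) as a modest step, so among these three compounds an aromatic ring at this place does not by itself go with the higher number of compound 1, and the earlier exchange of benzyl for sec-butyl is not the only change here that lowers the number. Nothing on hand accounts for either step.

The compounds shown leave open whether the two methoxy groups contribute anything, since a plain phenyl on this nitrogen would be needed to separate them from the ring itself. Also open, going by these compounds, is how far this place tolerates other kinds of group, such as an amine, a carboxylic acid or a longer chain in place of sec-butyl.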